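The source may report more compounds than this note shows. Statements on the series, on what has been measured and on what is new or still open speak of the compounds shown alone.

Compound 2 `Nc1ncnc2c1ncn2CC(O)C(=O)OCCO` gives in a functional assay on Vero cells (Chlorocebus sabaeus) for cytotoxicity (on this read-out higher numbers stand for lower toxicity in this test and lower numbers for higher toxicity in this test), a value of > 400 ug/mL, which is a limit of the assay rather than a number. Compound 1 `CC(C)CCOC(=O)C(O)Cn1cnc2c(N)ncnc21` gives 400 ug/mL in this assay. For the measured compounds named here, the only measured step is a number no lower from compound 1 to compound 2 (the limit leaves the size open), whose size is left open by the limit of > 400 ug/mL in this assay, at which 1 of the 2 values shown sits. Compound 3 `CCCOC(=O)C(O)Cn1cnc2c(N)ncnc21` differs from compound 2 by methyl in place of hydroxy on a saturated chain carbon, two bonds along the chain from an oxygen next to a carbonyl group. Going by the values given here, no measured step shares this change, so nothing points to a shift in either direction. The step of a number no higher from compound 2 to compound 3 (the limit leaves the size open) is expected to stay within the scatter. Compound 3 is therefore estimated at 400 ug/mL, between 200 ug/mL and 800 ug/mL.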

Compound 3, minimum cytotoxic concentration: > 400 ug/mL
Compound 3 ended at the assay's limit; the forecaster's own chance of this, stated with the estimate: 50%; the middle value lies on the limit itself.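

In this assay compound 3 gives > 400 ug/mL, a limit of the assay, so the hydroxy of compound 2 is not needed for a value at this limit. Methyl in place of isopropyl at this position gives a number no lower from compound 1 to compound 3 (the limit leaves the size open). The step between compound 2 and compound 3 cannot be read, because both values are limits: the limit of > 400 ug/mL in this assay, at which 2 of the 3 values shown sit.

The compounds shown leave open how far any of these values lies past the limit. They also leave open whether an amine or a carboxylic acid at the end of this chain would stay at the limit.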